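The source may report more compounds than this note shows. Statements on the series, on what has been measured and on what is new or still open speak of the compounds shown alone.

In an ADME assay on Huh-7 cells (Homo sapiens) for cytotoxicity (a higher number here means that more compound is tolerated, a lower number that less compound is tolerated), three close relatives built on one shared core have been measured. Compound 1 `O=c1cc(CNCc2ccccc2)oc2ccc(O)c(O)c12` gives > 100000 nM, which is a limit of the assay rather than a number. Compound 2 `O=c1cc(CNCc2ccc(F)cc2)oc2ccc(O)c(O)c12` gives > 100000 nM, again only a limit. Among the measured compounds shown here, compound 3 `O=c1cc(CNCc2ccc(I)cc2)oc2ccc(O)c(O)c12` gives 41700 nM, the single true number among the three, so it alone sits at a readable point. The step of an at least 2.3-fold lower number from compound 1 to compound 3 (0.37 log units; beyond the scatter) and the step of an at least 2.3-fold lower number from compound 2 to compound 3 (0.37 log units; beyond the scatter) both point the same way, while there is a step that the two limits leave unreadable from compound 1 to compound 2. Compound 4 `O=c1cc(CNCc2ccc([N+](=O)[O-])cc2)oc2ccc(O)c(O)c12` differs from compound 3 by nitro in place of iodo on an aromatic carbon. For the measured compounds named here, no measured step swaps iodo for nitro, so the halogen steps give only a loose guide. From compound 3 the expected move is a 1.7-fold higher number from compound 3 to compound 4 (0.22 log units; within the scatter). Compound 4 is thus estimated at 70000 nM, within a range from 25000 nM to 150000 nM.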

Compound 4, half-maximal cytotoxic concentration: 73300 nM
Estimate against measurement, compound 4: 1.0-fold (0.02 log units) below; measured number inside the range.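

Nitro in place of iodo gives a 1.8-fold higher number from compound 3 to compound 4 (0.24 log units; within the scatter), so in this assay these two groups cannot be told apart at this position. Set against the compounds with hydrogen and fluoro, nitro gives an at least 1.3-fold lower number from compound 2 to compound 4 (0.13 log units; that floor lies within the scatter) and an at least 1.3-fold lower number from compound 1 to compound 4 (0.13 log units; that floor lies within the scatter), so unlike the iodo steps, neither floor clears the scatter. Both steps remain floors, not full sizes, because compound 1 and compound 2 stand at a limit: the limit of > 100000 nM in this assay, at which 2 of the 4 values shown sit.

As far as these compounds go, whether the true gap from those two compounds to compound 4 is large stays open. So does how an amine or a carboxylic acid at this position would compare with nitro and iodo.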